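The source may report more compounds than this note shows. Statements on the series, on what has been measured and on what is new or still open speak of the compounds shown alone.

In a functional assay on NTUB1 cells (Homo sapiens) for cytotoxicity, read by MTT assay, with a stated time of 48 h (a lower number here means a stronger inhibitor, a higher number a weaker inhibitor), compound 1 `C=C1CC[C@@H]2[C@](C)(COC(=O)CC)[C@H](OC(=O)CC)CC[C@@]2(C)[C@@H]1CCc1ccoc1` gives 42900 nM and compound 2 `C=C1[C@H](O)C[C@@H]2[C@](C)(COC(=O)CC)[C@H](OC(=O)CC)CC[C@@]2(C)[C@@H]1CCc1ccoc1` gives 29600 nM, so the two stand within the usual scatter of each other. Compound 3 `C=C1CC[C@@H]2[C@](C)(COC(=O)CC)[C@H](OC(=O)CC)CC[C@@]2(C)[C@@H]1CC(OC(=O)CC)c1ccoc1` is still unmeasured. It differs from compound 1 by propanoyloxy in place of hydrogen on a saturated chain carbon bound to an aromatic carbon and a saturated chain carbon, with propanoyloxy in place of hydrogen on a saturated chain carbon bound to an aromatic carbon and a saturated chain carbon. Among the measured compounds shown here, the only measured step, a 1.4-fold lower number from compound 1 to compound 2 (0.16 log units; within the scatter), is a different change, hydroxy in place of hydrogen on a saturated ring carbon, and it stays within the scatter. It bears only indirectly, and no step beyond the scatter is expected. The expected step is a 1.1-fold lower number from compound 1 to compound 3 (0.05 log units; within the scatter). Compound 3 is estimated at 38000 nM, with an expected range of 15000 nM to 90000 nM.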

Compound 3, half-maximal inhibitory concentration: 89700 nM
The estimate for compound 3 lay 2.4-fold (0.37 log units) below the measured number, and the stated range covers the measured number.
By their numbers in this assay, from the lowest: compounds 2 and 1 (each within the scatter of the next); then compound 3.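

In this assay, propanoyloxy in place of hydrogen on a saturated chain carbon bound to an aromatic carbon and a saturated chain carbon gives a 2.1-fold higher number from compound 1 to compound 3 (0.32 log units; beyond the scatter), a modest step toward a weaker inhibitor. The earlier hydroxy change on a saturated ring carbon stayed within the scatter, so this is the first change shown to move the number beyond it. Nothing measured here accounts for the step. On these data alone, whether hydroxy, an amine or a longer ester chain on this same chain carbon would shift the number as far remains open.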